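Tolerance in Cells: From Compound 3 to Compound 4

The source may report more compounds than this note shows. Statements on the series, on what has been measured and on what is new or still open speak of the compounds shown alone.

compound 1, `COc1ccc([C@H]2CC(=O)N(C(C)=O)C2)cc1OC1CCCC1`, gives > 10000 nM
compound 2, `COc1ccc([C@H]2CC(=O)N(c3ccccc3C)C2)cc1OC1CCCC1`, gives > 10000 nM
compound 3, `COc1ccc([C@H]2CC(=O)N(c3cccc(NCCCc4ccccc4)c3)C2)cc1OC1CCCC1`, gives > 10000 nM

All three values come from a functional assay on HEK293 cells (Homo sapiens) for cytotoxicity; a higher number here means that more compound is tolerated, a lower number that less compound is tolerated. Each of them is a limit of the assay rather than a number: compound 1 shows only the limit > 10000 nM. Compound 2 likewise shows only the limit > 10000 nM. Compound 3 also sits at the limit, > 10000 nM. Going by the values given here, the one change that links two measured compounds, a step that the two limits leave unreadable from compound 1 to compound 2, therefore cannot be read in size, and the whole picture rests on (the limit of > 10000 nM in this assay, at which 3 of the 3 values shown sit).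

Compound 4, `COc1ccc([C@H]2CC(=O)N(c3cccc(NS(=O)(=O)c4c(F)cccc4F)c3)C2)cc1OC1CCCC1`, is not yet measured. It differs from compound 3 in one place: (2,6-difluorophenyl)sulfonyl in place of 3-phenylpropyl on a nitrogen on an aromatic ring. Among the compounds with values here, no measured step matches this change, and the only measured step in this assay is unreadable, so there is no basis for expecting any shift beyond the scatter. Compound 4 is therefore expected to sit at the same limit as compound 3, with an estimated step that the limit leaves unreadable from compound 3 to compound 4. For compound 4 the estimated value in this assay is 12000 nM, between 3000 nM and 40000 nM, most likely reported again only as a limit.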

Compound 4, half-maximal cytotoxic concentration: > 10000 nM
Compound 4 ended at the assay's limit; the forecaster's own chance of this, stated with the estimate: 80%; the middle value lies beyond the limit too.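

Compound 3 and compound 4 both stand at a limit of the assay, and the step between them cannot be read in size: the limit of > 10000 nM in this assay, at which 4 of the 4 values shown sit.

The compounds shown leave open the concentration at which any of them would reach a half-maximal effect in this assay, and whether any change to their groups would alter it.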